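Quinolin-2-ylmethoxy in Place of Butoxy on a Hydroxamic Acid

A few compounds are considered here, and "the series" means these few. Any claim that something is new, unique, unknown or untested is made for them only; others in the source may bear on it.

Measured so far:
compound 1, `CCCCOc1ccc(C(C)N(O)C=O)cc1`, 1900 nM
compound 2, `CCCCOc1ccc(C(C)N(O)C(=O)c2ccccc2)cc1`, 1300 nM
compound 3, `CCCCOc1ccc(C(CC)N(O)C(C)=O)cc1`, 740 nM

All three numbers come from an assay on RBL-1 cells for inhibition of Polyunsaturated fatty acid 5-lipoxygenase (Rattus norvegicus); a higher number here means a weaker inhibitor, a lower number a stronger inhibitor. Compound 2 stands second highest of the three, with compound 1 nearest at 1900 nM and compound 3 furthest at 740 nM; both gaps are within the scatter, so the three compounds read as a single level. Within the data shown here, the one step that can be followed, a 1.5-fold lower number from compound 1 to compound 2 (0.16 log units; within the scatter), changes only the carbonyl substituent and stays within the scatter.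

Compound 4, `CC(c1ccc(OCc2ccc3ccccc3n2)cc1)N(O)C(=O)c1ccccc1`, differs from compound 2 by quinolin-2-yl in place of propyl on a saturated chain carbon bound to an oxygen on an aromatic ring. Among the measured compounds shown here, none of the measured steps touches this chain: the step from compound 1 to compound 2 sits on the carbonyl carbon, and compound 3 against compound 1 changes the carbon next to the nitrogen while the chain on the aromatic oxygen is kept. For the measured compounds named here, the data therefore give no measured step to scale this change, and the expectation rests on compound 2 at 1300 nM as the starting point, with wide uncertainty. Compound 4 is expected to give 300 nM in this assay, with a range from 60 nM to 1500 nM, which corresponds to an estimated step of a 4.3-fold lower number from compound 2 to compound 4 (0.64 log units; beyond the scatter).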

Compound 4, half-maximal inhibitory concentration: 400 nM
The estimate for compound 4 lay 1.3-fold (0.12 log units) below the measured number, and the stated range covers the measured number.
By their numbers in this assay, from the lowest: compounds 4, 3, 2 and 1 (each within the scatter of the next, the first and the last beyond it).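

In this assay, among these compounds, quinolin-2-yl in place of propyl on a saturated chain carbon bound to an oxygen on an aromatic ring gives a 3.3-fold lower number from compound 2 to compound 4 (0.51 log units; beyond the scatter), a modest change but one that clears the scatter, which the one step available earlier, on the carbonyl carbon, did not. This shows that the number responds to the group at this place, and that a group of 10 heavy atoms with two aromatic rings can replace one of 3 heavy atoms with no ring and still give the lower number. No measurement bearing on the origin of this step is available, so the result stands as an observation only.

As far as these compounds go, the change is seen on a single pair, with phenyl on the carbonyl carbon, so it remains open whether the same swap would give a similar step with the hydrogen of compound 1 on that carbon. From the compounds shown here alone, it also remains open whether the ring nitrogen of quinolin-2-yl has any part in the step, a question that naphthalen-2-yl or a plain phenyl at the same place would address.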